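Replacing the ethynyl group of compound 2

The compounds below may be only part of what the source reports. "The series", "measured", "known", "first", "only" and "open" are said of these compounds alone.

Compound 1 `O=C(CCc1cccc2c1B(O)OC2)Nc1ccc(Br)cc1`: 9200 nM
Compound 2 `C#Cc1ccc(NC(=O)CCc2cccc3c2B(O)OC3)cc1`: 6300 nM

Going by the values given here, both compounds share one core and have been measured in a functional assay on SK-OV-3 cells (Homo sapiens) for antiproliferative activity, read by MTT assay, with a stated time of 72 h; on this read-out higher numbers stand for weaker inhibition and lower numbers for stronger inhibition. There, compound 2 gives 6300 nM, which cannot be told apart from compound 1 at 9200 nM. Among the compounds with values here, only two numbers exist so far, so compound 2 is the natural reference for the next comparison.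

Compound 3 `CC(C)(C)OC(=O)Nc1ccc(NC(=O)CCc2cccc3c2B(O)OC3)cc1` puts (tert-butoxycarbonyl)amino in place of ethynyl on an aromatic carbon, para to a large group: (tert-butoxycarbonyl)amino in place of ethynyl on an aromatic carbon.

Within the data shown here, one measured step bears on this change, namely a 1.5-fold lower number from compound 1 to compound 2 (0.16 log units; within the scatter). It replaced bromo with ethynyl on an aromatic carbon and stayed small. Among the measured compounds shown here, that gives a hint that changes at this place may matter little, but it is a single step, and no measured compound carries anything like the entering group. The data therefore offer no direction, and no shift beyond the scatter in this assay is expected, though with real uncertainty. The expected change is a 1.3-fold higher number from compound 2 to compound 3 (0.10 log units; within the scatter). For compound 3, the estimate is 8000 nM, with an expected range of 3000 nM to 20000 nM.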

Compound 3, half-maximal inhibitory concentration: > 100000 nM
Compound 3: only a limit was reported; the forecaster's own chance of this, stated with the estimate: 10%; middle value at least 12-fold (1.09 log units) from the limit.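

In this assay compound 3 gives > 100000 nM, which is a limit of the assay and not a number. The position is not indifferent to what it carries: the exchange of bromo for ethynyl stayed small, at a 1.5-fold lower number from compound 1 to compound 2 (0.16 log units; within the scatter), whereas (tert-butoxycarbonyl)amino brings an at least 15-fold higher number from compound 2 to compound 3 (1.20 log units; beyond the scatter) and an at least 10-fold higher number from compound 1 to compound 3 (1.03 log units; beyond the scatter), both beyond the scatter. These two steps give only the smallest possible size of the change, and how much further the true number lies cannot be read from this result: the limit of > 100000 nM in this assay, at which 1 of the 3 values shown sits.

Still open, going by these compounds, is whether the loss of activity belongs to the whole (tert-butoxycarbonyl)amino group or to only one part of it, such as the bulky tert-butyl end, and a free amine or a small acetamide at the same place would help to separate these two readings. Also open, on these data alone, is whether any other group here, such as a carboxylic acid or a short alkyl chain, could give a number clearly lower than that of compound 2, at 6300 nM.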